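The source may report more compounds than this note shows. Statements on the series, on what has been measured and on what is new or still open speak of the compounds shown alone.

For the measured compounds named here, compound 2 `CCNc1nc(N)nc2ccccc12` stands second highest of the three numbers so far in an ADME assay on HEK293 cells for agonist activity at Toll-like receptor 8 (Homo sapiens), read by a luciferase reporter, with a stated time of 6 h (a lower number here means that less compound is needed, a higher number that more compound is needed for the effect), giving 0.77 uM. Compound 1 `CNc1nc(N)nc2ccccc12` gives 6.87 uM, and compound 3 `CCCC(C)Nc1nc(N)nc2ccccc12` gives 0.17 uM. The step to compound 4 `COCCCNc1nc(N)nc2ccccc12` is methoxymethyl in place of hydrogen on a saturated chain carbon, two bonds along the chain from a nitrogen on an aromatic ring.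

Going by the values given here, two measured steps bear on this change, both of them adding carbon to the chain that hangs from the nitrogen on the aromatic ring. The step of an 8.9-fold lower number from compound 1 to compound 2 (0.95 log units; beyond the scatter) and the step of a 4.5-fold lower number from compound 2 to compound 3 (0.66 log units; beyond the scatter) were each beyond the scatter and pointed the same way, toward a lower number. Among the compounds with values here, the change to compound 4 likewise lengthens that chain, though with an oxygen in it rather than carbon alone, and no measured compound shows what that oxygen does. A modest lowering is therefore expected, a 3.1-fold lower number from compound 2 to compound 4 (0.49 log units; beyond the scatter), smaller than the full gain seen for compound 3. Compound 4 is estimated at 0.25 uM in this assay, within a range from 0.08 uM to 0.8 uM.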

Compound 4, minimum effective concentration: 0.01 uM
Estimate against measurement, compound 4: 25-fold (1.40 log units) above; the measured number lies below the stated range.
By their numbers in this assay, from the lowest: compound 4; then compound 3; then compound 2; then compound 1.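

In this assay, the 3-methoxypropyl chain on the nitrogen on the aromatic ring gives the lowest number of the four compounds, with a 77-fold lower number from compound 2 to compound 4 (1.89 log units; beyond the scatter) and a 690-fold lower number from compound 1 to compound 4 (2.84 log units; beyond the scatter), a larger drop than either earlier step along this chain had shown. The 1-methylbutyl group of compound 3 had held the lowest number until then, yet the chain carrying oxygen goes clearly further, with a 17-fold lower number from compound 3 to compound 4 (1.23 log units; beyond the scatter), so at this position the all-carbon chains do not mark the limit of the gain. Nothing measured here accounts for this gain.

Going by these compounds, what a butyl or pentyl chain would give at this position, and so whether the oxygen or the chain length carries the step, stays open. So does the effect of a hydroxyl or an amine in place of the methoxy group.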